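This account rests on a few compounds, and the source may have more. Where it says the series, first, only, none or still open, it means among the compounds named here.

Measured compounds and their values:

Compound 1, `ClCc1ccccc1Cn1cnc2c(Cl)nc(Cl)nc21`: 4160 nM
Compound 2, `ClCc1ccccc1Cn1cnc2c(Cl)ncnc21`: 10900 nM
Compound 3, `ClCc1cccc(Cn2cnc3ncnc(Cl)c32)c1`: 3460 nM

All three were tested in a functional assay on SF-268 cells (Homo sapiens) for cytotoxicity, read by sulforhodamine B assay, with a stated time of 48 h; a higher number here means a weaker inhibitor of growth, a lower number a stronger inhibitor of growth. In this assay compound 2 gives 10900 nM, and compound 1, which carries one more chloro group, gives 4160 nM. The change between them is chloro in place of hydrogen on an aromatic carbon, and it brought a 2.6-fold lower number from compound 2 to compound 1 (0.42 log units; beyond the scatter). Compound 3 gives 3460 nM; its value lies close to that of compound 1, within the usual scatter, and it is lower than that of compound 2. Compound 3 is built from the same atoms as compound 2, joined differently; the difference between the two cores is not broken down here.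

Compound 4, `ClCc1cccc(Cn2cnc3nc(Cl)nc(Cl)c32)c1`, has not yet been measured. It differs from compound 3 by chloro in place of hydrogen on an aromatic carbon, and the place of that change is described in exactly the same words as the place of the change from compound 2 to compound 1, so the two are the same change on two related cores. The expectation for compound 4 therefore rests on a single earlier observation: because the change from compound 2 to compound 1 gave a 2.6-fold lower number from compound 2 to compound 1 (0.42 log units; beyond the scatter), a step of similar size, a 2.5-fold lower number from compound 3 to compound 4 (0.39 log units; beyond the scatter), is expected from compound 3 to compound 4. Going by the values given here, with only one precedent, a wide range is kept. Compound 4 is estimated at 1400 nM, with the likely range from 600 nM to 3500 nM.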

Compound 4, concentration for total growth inhibition: 3800 nM
Beside the measured number, compound 4's estimate is 2.7-fold (0.43 log units) below it, outside the stated range (above it).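

In this assay, placing a chloro group on the aromatic carbon between two ring nitrogen atoms gave a 1.1-fold higher number from compound 3 to compound 4 (0.04 log units; within the scatter), so on this core the change cannot be told apart from repeat-to-repeat variation. Set beside the earlier case, the same change did not carry over from one core to the other with the same effect: the same change on two cores in this assay, a 2.6-fold lower number (0.42 log units; beyond the scatter) from compound 2 to compound 1 and a 1.1-fold higher number (0.04 log units; within the scatter) from compound 3 to compound 4, 2.9-fold (0.46 log units) apart, beyond the scatter of two such steps This shows that, in this series, the effect of adding this chloro group on the core of compound 2 is no safe guide to its effect on the core of compound 3, but with a single pair on each core, it does not show why the two results part ways, nor which of them is more typical of related compounds.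

The compounds shown leave open whether a different group in that same place, such as an amine or a methoxy group, would also act differently on the two cores. From the compounds shown here alone, it also remains open whether the two cores would still part ways for this chloro change if the chloromethyl group were replaced by a hydroxymethyl group or a longer chain.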